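A few compounds are considered here, and "the series" means these few. Any claim that something is new, unique, unknown or untested is made for them only; others in the source may bear on it.

Measured in a functional assay on HONE1 cells for cytotoxicity against HONE1 cell line (Homo sapiens); a lower number here means a stronger inhibitor, a higher number a weaker inhibitor:
compound 1 `CCC1C(=O)N(CCCCCCOc2ccc(Cl)cc2)/C(=N\C#N)N1c1ccncc1` gives 3870 nM;
compound 2 `CCC1C(=O)N(CCCCCCCOc2ccc(Cl)cc2)/C(=N\C#N)N1c1ccncc1` gives 3230 nM;
compound 3 `N#C/N=C1\N(CCCCCCOc2ccc(Cl)cc2)C(=O)CCN1c1ccncc1` gives 577 nM.

Compounds 1 and 2 share one core, while compound 3 is built on another; how the two cores differ is not broken down here. Within the first pair, the change from compound 1 to compound 2 is (4-chlorophenoxy)methyl in place of 4-chlorophenoxy on a saturated chain carbon, six bonds along the chain from an amide-type nitrogen in a ring, and in this assay it made a 1.2-fold lower number from compound 1 to compound 2 (0.08 log units; within the scatter). Compound 3 stands lowest of the three measured numbers, and its distance from both compound 1 and compound 2 lies beyond the scatter.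

Compound 4 `N#C/N=C1\N(CCCCCCCOc2ccc(Cl)cc2)C(=O)CCN1c1ccncc1` has not yet been measured. It differs from compound 3 by (4-chlorophenoxy)methyl in place of 4-chlorophenoxy on a saturated chain carbon, six bonds along the chain from an amide-type nitrogen in a ring, the same change as that from compound 1 to compound 2, now made on the core of compound 3. Since the measured pair gave a 1.2-fold lower number from compound 1 to compound 2 (0.08 log units; within the scatter), a step of about the same size is expected here, a 1.2-fold lower number from compound 3 to compound 4 (0.06 log units; within the scatter), though this rests on one example only. Compound 4 is therefore expected to come in at about 500 nM in this assay, most likely between 250 nM and 1000 nM.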

Compound 4, half-maximal inhibitory concentration: 3440 nM
For compound 4 the middle estimate is 6.9-fold (0.84 log units) below the measured one; the measured number lies above the stated range.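

On the core of compound 3, this assay gives a 6.0-fold higher number from compound 3 to compound 4 (0.78 log units; beyond the scatter), so replacing 4-chlorophenoxy with (4-chlorophenoxy)methyl at this place does not have the same outcome as on the core of compound 1. The size of this step on one core therefore could not be carried over to the other, and the two cores do not respond alike to the change: the same change on two cores in this assay, a 1.2-fold lower number (0.08 log units; within the scatter) from compound 1 to compound 2 and a 6.0-fold higher number (0.78 log units; beyond the scatter) from compound 3 to compound 4, 7.1-fold (0.85 log units) apart, beyond the scatter of two such steps. This rests on a single pair of compounds for each core, so it shows that the change can depend on the core, but it gives neither a rule for the wider series nor a reason for the difference.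

The compounds shown leave open how either core would respond to a still longer chain, such as 2-(4-chlorophenoxy)ethyl at the same place. They also leave open whether the difference between the cores would persist if the chlorine on the phenoxy ring gave way to a fluorine or a methoxy group.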